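Phenyl replacing benzyloxy: a step from one assay limit

This account rests on a few compounds, and the source may have more. Where it says the series, first, only, none or still open, it means among the compounds named here.

Compound 1 `Cc1cc(C)c(S(=O)(=O)N2CCN(C3CN4CCC3CC4)CC2)c(C)c1`: in an ADME assay on HCT-116 cells (Homo sapiens) for cytotoxicity, read by CellTiter-Glo, with a stated time of 72 h (on this read-out lower numbers stand for stronger inhibition and higher numbers for weaker inhibition), compound 1 gives > 5000 nM, which is a limit of the assay rather than a number.
Compound 2 `CC1CCN(C2CCN(S(=O)(=O)c3ccc(OCc4ccccc4)cc3)CC2)CC1`: in this assay compound 2 gives > 5000 nM, again a limit of the assay.
Compound 3 `COc1cc(C)ccc1S(=O)(=O)N1CCC(N2CCC(C)CC2)CC1`: in this assay compound 3 gives > 5000 nM, also a limit of the assay.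

Compound 2 therefore stands where every measured compound in this set stands: at the limit of > 5000 nM in this assay, at which 3 of the 3 values shown sit. Going by the values given here, none of the three gives a number, so no ordering among them can be read, and no measured step between any two of them is available to lean on.

Compound 4 `CC1CCN(C2CCN(S(=O)(=O)c3ccc(-c4ccccc4)cc3)CC2)CC1` differs from compound 2 in one place: phenyl in place of benzyloxy on an aromatic carbon. The change removes the oxygen-bearing linker and brings the outer ring directly onto the aromatic carbon, but nothing in the measured set shows what such a change does in this assay.

With all three measured values sitting at the same limit, the step that the limit leaves unreadable from compound 2 to compound 4 is expected to be none beyond the scatter, meaning compound 4 is most likely to be reported as a limit once more. The estimate for compound 4 is 9000 nM, with a range from 3000 nM to 30000 nM.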

Compound 4, half-maximal inhibitory concentration: > 5000 nM
Compound 4 gave a limit, no number (the forecaster's own chance of this, stated with the estimate: 80%); the middle value lies beyond the limit too.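

No size can be read for the step between compound 2 and compound 4, because both stay at the same limit rather than giving numbers: the limit of > 5000 nM in this assay, at which 4 of the 4 values shown sit.

The compounds shown leave open whether phenyl in place of benzyloxy changes anything in this assay, and what change to these structures, if any, would bring a measurable value.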